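A few compounds are considered here, and "the series" means these few. Any claim that something is new, unique, unknown or untested is made for them only; others in the source may bear on it.

Measured in a functional assay on K562 cells (Homo sapiens) for inhibition, read by sulforhodamine B assay, with a stated time of 48 h; on this read-out higher numbers stand for weaker inhibition of growth and lower numbers for stronger inhibition of growth:
- Compound 1 `CCOC(=O)c1nn(-c2ccccc2)c(-c2ccc(Cl)cc2)c1CNC(C)(C)C` gives 57600 nM; > 559000 nM (2 entries)
- Compound 2 `CCOC(=O)c1nn(-c2ccccc2)c(-c2ccccc2)c1CNC(C)(C)C` gives 9620 nM; 113000 nM (2 entries)
- Compound 3 `CC(C)(C)NCc1c(C(=O)O)nn(-c2ccccc2)c1-c1ccc(Cl)cc1` gives 364000 nM

Compound 3 is the only one of the three with a single number (364000 nM). The other two each carry two entries that do not settle on one number, and both entries of compound 2 lie lower than the value of compound 3.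

The next compound to be tested is compound 4 `CC(C)(C)NCc1c(C(=O)O)nn(-c2ccccc2)c1-c1ccccc1`. Going from compound 3 to compound 4, hydrogen takes the place of chloro on an aromatic carbon, para to a large group, so that 4-chlorophenyl becomes phenyl (hydrogen in place of chloro on an aromatic carbon).

Within the data shown here, no measured step speaks directly to this change. The nearest guide is compound 2 (9620 nM; 113000 nM (2 entries)), whose entries lie lower than the corresponding entries of compound 1. Those entries sit far apart (the several entries of compound 2 in this assay, 9620 nM; 113000 nM (2 entries)), so the guide is a loose one. On that basis a downward step beyond the scatter is expected, towards stronger inhibition of growth (a 4.6-fold lower number from compound 3 to compound 4 (0.66 log units; beyond the scatter)). For compound 4 the estimated value in this assay is 80000 nM with an expected range from 20000 nM to 350000 nM.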

Compound 4, concentration for 50% growth inhibition: > 716000 nM
Compound 4: only a limit was reported (the forecaster's own chance of this, stated with the estimate: 15%); middle value at least 8.9-fold (0.95 log units) from the limit.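

In this assay compound 4 gives > 716000 nM, which is a limit of the assay and not a number. On these data alone, with the carboxylic acid in place, the change from 4-chlorophenyl to phenyl can be read only as an at least 1.9-fold higher number from compound 3 to compound 4 (0.29 log units; that floor lies within the scatter), so this position shows no lower number on losing the chloro, and the size of the true step stays unknown. The ethyl ester pair had offered the only earlier view of this change, and it gives no firm counterpart to the acid pair, as the entries of compound 1 and those of compound 2 each stay far apart: the several entries of compound 2 in this assay, 9620 nM; 113000 nM (2 entries)

The compounds shown leave open whether fluoro, methyl or methoxy on the aromatic carbon that carries the chloro in compound 3 would give a value that can be read as a number. They also leave open how an amide in place of the carboxylic acid, or a smaller amine such as isopropylamine in place of the tert-butylamine, would read on the phenyl and 4-chlorophenyl series.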